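Pyrimidinylsulfanyl in Place of Ethyl on the Side Chain

This account rests on a few compounds, and the source may have more. Where it says the series, first, only, none or still open, it means among the compounds named here.

Measured so far in a functional assay (trachea) with Cavia porcellus as the target; a lower number here means a stronger inhibitor, a higher number a weaker inhibitor:
Compound 1 `CCn1nc(-c2cccnc2)c2ccccc2c1=O` gives 1320 nM
Compound 2 `CCCCn1nc(-c2cccnc2)c2ccccc2c1=O` gives 2290 nM
Compound 3 `O=c1c2ccccc2c(-c2cccnc2)nn1CCSc1nccs1` gives 10500 nM

Compound 2 sits close to compound 1, the two within the scatter a 1.7-fold higher number from compound 1 to compound 2 (0.24 log units; within the scatter), and apart from compound 3 by a 4.6-fold higher number from compound 2 to compound 3 (0.66 log units; beyond the scatter). Compound 4 `O=c1c2ccccc2c(-c2cccnc2)nn1CCSc1ncccn1` differs from compound 2 by (pyrimidin-2-yl)sulfanyl in place of ethyl on a saturated chain carbon, two bonds along the chain from an aromatic nitrogen.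

The step that bears most directly on this change is a 4.6-fold higher number from compound 2 to compound 3 (0.66 log units; beyond the scatter), where a five-membered heteroaryl sulfanyl group entered at the same place; an 8.0-fold higher number from compound 1 to compound 3 (0.90 log units; beyond the scatter) points the same way. A six-membered ring entering at the same spot is expected to behave alike, so a modest weakening is expected, a 3.5-fold higher number from compound 2 to compound 4 (0.54 log units; beyond the scatter). Compound 4 is estimated at 8000 nM, with a range from 3000 nM to 22000 nM.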

Compound 4, half-maximal inhibitory concentration: 11000 nM
Estimate against measurement, compound 4: 1.4-fold (0.14 log units) below; low and high end bracket the measured number.
By their numbers in this assay, from the lowest: compounds 1 and 2 (each within the scatter of the next); then compounds 3 and 4 (each within the scatter of the next).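

In this assay, the step of a 1.0-fold higher number from compound 3 to compound 4 (0.02 log units; within the scatter) shows no difference between pyrimidin-2-yl and 1,3-thiazol-2-yl on the sulfur. The weakening first seen with the thiazole therefore recurs with a six-membered ring, at a 4.8-fold higher number from compound 2 to compound 4 (0.68 log units; beyond the scatter) and at an 8.3-fold higher number from compound 1 to compound 4 (0.92 log units; beyond the scatter), so it is not confined to one heteroaryl group. Nothing available explains why these sulfanyl side chains give weaker inhibition.

From the compounds shown here alone, whether a phenyl ring on the same sulfur, or a side chain ending in an amine or a carboxylic acid, would bring the number back towards that of compound 1 stays open.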